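The compounds below may be only part of what the source reports. "The series", "measured", "known", "first", "only" and "open" are said of these compounds alone.

Compound 1 has the structure `CC1CCN(C2CCN(S(=O)(=O)c3cccnc3Cl)CC2)CC1`. In an ADME assay on HCT-116 cells (Homo sapiens) for cytotoxicity, read by CellTiter-Glo, with a stated time of 72 h (a lower number here means a stronger inhibitor, a higher number a weaker inhibitor), compound 1 gives > 10000 nM, which is a limit of the assay and not a number. Compound 2 has the structure `Cc1cc(C)c(S(=O)(=O)NC2CCN(C3CCN(C)CC3)CC2)c(C)c1`. In this assay compound 2 gives > 5000 nM, also a limit. Compound 3 has the structure `Cc1cc(C)c(S(=O)(=O)N2CCC(N3CCC(Cc4ccccc4F)CC3)CC2)c(C)c1`. In this assay compound 3 gives > 5000 nM, again a limit.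

Compound 1 therefore stands at the limit of > 10000 nM in this assay, at which 1 of the 3 values shown sits, while the other two measured compounds sit at the limit of > 5000 nM in this assay, at which 2 of the 3 values shown sit. Among the compounds with values here, no step between measured compounds is available. Compound 4 has the structure `CCc1ccc(S(=O)(=O)N2CCC(N3CCC(C)CC3)CC2)cc1`; it differs from compound 1 in one place: 4-ethylphenyl in place of 2-chloropyridin-3-yl on a sulfonyl sulfur. With every measured value a limit, no change beyond the scatter is expected for this step. Compound 4 is expected to give 15000 nM, between 5000 nM and 50000 nM, a step that the limit leaves unreadable from compound 1 to compound 4.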

Compound 4, half-maximal inhibitory concentration: > 5000 nM
Compound 4 ended at the assay's limit; the forecaster's own chance of this, stated with the estimate: 80%; the middle value does not contradict the limit.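

The values of compound 1 and compound 4 in this assay are both limits, so no step can be read between them. The compounds shown leave open whether any of these structures gives a measurable value in this assay.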